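The source may report more compounds than this note shows. Statements on the series, on what has been measured and on what is new or still open speak of the compounds shown alone.

In an assay on Sf9 cells for inhibition of protein deacetylase HDAC6 (Homo sapiens), read by fluorescence, with a stated time of 40 min, tested at 100 nM (a higher number here means more inhibition at the concentration tested (going by the name of the read-out), a lower number less inhibition), compound 3 `Cc1ccccc1-c1nc(CNc2ccc(C(=O)NO)cc2)n(-c2ccccc2)n1` gives 53.2%. Compound 1 `COc1ccc(-c2nc(CNc3ccc(C(=O)NO)cc3)n(-c3ccccc3)n2)cc1` gives 77.6% and compound 2 `O=C(NO)c1ccc(NCc2nc(-c3ccc(Br)cc3)nn2-c2ccccc2)cc1` gives 54.7%, so compound 3 holds the lowest of the three numbers, though its gap to compound 2 lies within the scatter. Compound 4 `O=C(NO)c1ccc(NCc2nc(-c3ccccc3Cl)nn2-c2ccccc2)cc1` differs from compound 3 by chloro in place of methyl on an aromatic carbon. For the measured compounds named here, two measured steps bear on this change: a number 22.9 percentage points lower from compound 1 to compound 2 (beyond the scatter), and a number 1.5 percentage points lower from compound 2 to compound 3 (within the scatter), the second showing that a halogen-bearing phenyl and a methyl-bearing phenyl gave similar numbers. Going by the values given here, with only that small step as a guide, the expected step is a number 1.2 percentage points lower from compound 3 to compound 4 (within the scatter), within the scatter. Compound 4 is therefore estimated at 52%, with a range from 38% to 66%.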

Compound 4, a percentage reported as inhibition, at one concentration (the size of the read-out at that concentration, not a potency): 75%
Compound 4: the middle estimate sits 23 percentage points below what was measured; the measured number lies above the stated range.
By their numbers in this assay, from the lowest: compounds 3 and 2 (each within the scatter of the next); then compounds 4 and 1 (each within the scatter of the next).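

In this assay, chloro in place of methyl on this phenyl ring gives a number 21.8 percentage points higher from compound 3 to compound 4 (beyond the scatter), so two groups of one heavy atom each at the same place do not behave alike. Against the 4-bromophenyl compound the result is a number 20.3 percentage points higher from compound 2 to compound 4 (beyond the scatter), while against the 4-methoxyphenyl compound it is a number 2.6 percentage points lower from compound 1 to compound 4 (within the scatter), so carrying a halogen does not by itself fix the number on this ring. No measured property is available to explain these steps.

Going by these compounds, it remains open whether fluoro, trifluoromethyl or an amine at this place would track chloro or methyl. On these data alone, it also remains open whether chloro would hold its number elsewhere on the ring.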